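The compounds below may be only part of what the source reports. "The series", "measured", "known", "first", "only" and "open" are said of these compounds alone.

Compound 2 `CC(C)(Oc1ccccc1)C1OCC(C/C=C\CCC(=O)O)C(c2cccnc2)O1` stands lowest of the two numbers recorded in a functional assay for inhibition, with Homo sapiens as the target (on this read-out lower numbers stand for tighter binding and higher numbers for weaker binding), where compound 2 gives 75.9 nM. Its nearest neighbour, compound 1 `N#Cc1ccccc1C1OCC(C/C=C\CCC(=O)O)C(c2cccnc2)O1`, gives 245 nM in this assay, a gap described by a 3.2-fold lower number from compound 1 to compound 2 (0.51 log units; beyond the scatter). Compound 3 `CC(C)(Oc1ccccc1Br)C1OCC(C/C=C\CCC(=O)O)C(c2cccnc2)O1` differs from compound 2 by bromo in place of hydrogen on an aromatic carbon. Within the data shown here, that single step from compound 1 to compound 2 concerns an exchange on a saturated ring carbon and does not touch a bromo for hydrogen change on an aromatic carbon, so no measured step bears directly on compound 3. He therefore expects a step of a 1.2-fold lower number from compound 2 to compound 3 (0.07 log units; within the scatter) for compound 3, within the scatter, and estimates compound 3 at 65 nM, between 25 nM and 170 nM.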

Compound 3, dissociation constant: 63.1 nM
Compound 3: middle estimate off by 1.0-fold (0.01 log units), on the high side, within the range that was stated.
By their numbers in this assay, from the lowest: compounds 3 and 2 (each within the scatter of the next); then compound 1.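

In this assay, among these compounds, the step of a 1.2-fold lower number from compound 2 to compound 3 (0.08 log units; within the scatter) is the first reading at this aromatic carbon, ortho to a large group, and it lies within the scatter. Phenoxy to 2-bromophenoxy therefore adds one bromine atom with no discernible shift in the number, something the earlier exchange on the saturated ring carbon could not show. Nothing on hand accounts for this result.

On these data alone, it remains open whether fluoro, methoxy or an amine on this same carbon would also stay within the scatter. The compounds shown also give no reading for bromo on any other carbon of that ring.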